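Notes on N-aryl imide 5-lipoxygenase series: benzyl for phenyl

This account rests on a few compounds, and the source may have more. Where it says the series, first, only, none or still open, it means among the compounds named here.

Measured compounds:
compound 1 `NS(=O)(=O)c1ccc(N2C(=O)CC(C3CCCCC3=O)C2=O)cc1` — in an assay on cells (1-87 tumor cell line) for inhibition of Polyunsaturated fatty acid 5-lipoxygenase (Homo sapiens), with a stated time of 5 min (a lower number here means a stronger inhibitor, a higher number a weaker inhibitor), compound 1 gives 21300 nM
compound 2 `O=C1CCCCC1C1CC(=O)N(c2ccccc2)C1=O` — in this assay compound 2 gives 78300 nM
compound 3 `NS(=O)(=O)c1ccc(N2C(=O)CC(C3CCCCCC3=O)C2=O)cc1` — in this assay compound 3 gives 16200 nM

Compound 2 stands at the highest number of the three; its nearest neighbour is compound 1, and compound 3 lies furthest from it. Among the measured steps, a 3.7-fold higher number from compound 1 to compound 2 (0.57 log units; beyond the scatter) is the one that touches the substituent on the aromatic ring attached to the ring nitrogen, and it is modest but beyond the scatter. The other step, a 1.3-fold lower number from compound 1 to compound 3 (0.12 log units; within the scatter), concerns the ketone-bearing ring and stays within the scatter.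

The unmeasured compound 4 `O=C1CCCCC1C1CC(=O)N(Cc2ccccc2)C1=O` differs from compound 2 in one place: benzyl in place of phenyl on an amide-type nitrogen in a ring. Going by the values given here, no measured pair changes the link between the ring nitrogen and the aromatic ring, so neither step bears directly on this change; the only guide is that compound 2 already sits at the high end of the series, and the aromatic ring itself is kept. The expectation for this assay is therefore a step of no clear direction, with a wide range around the value of compound 2.

Compound 4 is estimated at 70000 nM, with a range from 25000 nM to 200000 nM. This estimate means a step of a 1.1-fold lower number from compound 2 to compound 4 (0.05 log units; within the scatter), which is expected to fall within the scatter.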

Compound 4, half-maximal inhibitory concentration: 36000 nM
Compound 4: the middle estimate sits 1.9-fold (0.29 log units) above what was measured, and the stated range covers the measured number.
By their numbers in this assay, from the lowest: compounds 3, 1 and 4 (each within the scatter of the next, the first and the last beyond it); then compound 2.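

In this assay, benzyl in place of phenyl on an amide-type nitrogen in a ring gives a 2.2-fold lower number from compound 2 to compound 4 (0.34 log units; beyond the scatter), the first measured sign that this position responds to a change in the group's link to the nitrogen while the aromatic ring itself is kept. The sulfamoyl step, a 3.7-fold higher number from compound 1 to compound 2 (0.57 log units; beyond the scatter), had shown only that a substituent on the aromatic ring matters, so compound 2 now has two single-change neighbours with lower numbers, and the new step is also modest. The entering benzyl adds carbon only, with no hydrogen-bond donor or acceptor in the group, and nothing on hand explains the step.

As far as these compounds go, it remains open whether a longer chain, such as 2-phenylethyl, continues the step or reverses it, and whether a pyridin-3-ylmethyl group on the same nitrogen behaves like benzyl. Also open, from the compounds shown here alone, is whether sulfamoyl on the benzyl ring, or 2-oxocycloheptyl in place of 2-oxocyclohexyl on the core of compound 4, would give steps of the size seen with the phenyl compounds.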